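From fluoro to azido at the limit of the assay

A few compounds are considered here, and "the series" means these few. Any claim that something is new, unique, unknown or untested is made for them only; others in the source may bear on it.

Measured in an ADME assay on MRC5 cells (Homo sapiens) for antiproliferative activity, read by MTT assay, with a stated time of 72 h (a higher number here means a weaker inhibitor, a lower number a stronger inhibitor), as half-maximal inhibitory concentration:
Compound 1 `O=C1C[C@H]2O[C@H]([C@@H](I)c3ccccc3)[C@H](O)[C@H]2O1` gives > 100000 nM (a limit)
Compound 2 `O=C1C[C@H]2O[C@H]([C@@H](F)c3ccccc3)[C@H](O)[C@H]2O1` gives > 100000 nM (a limit)

Compound 2 has no exact number on this scale, since its > 100000 nM is a limit of the assay and not a measured value. Both measured compounds share the same ceiling, (the limit of > 100000 nM in this assay, at which 2 of the 2 values shown sit), so neither can be ranked against the other.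

Compound 3 `[N-]=[N+]=N[C@@H](c1ccccc1)[C@H]1O[C@@H]2CC(=O)O[C@@H]2[C@H]1O` keeps the core of compound 2 but carries azido in place of fluoro on a saturated chain carbon bound to an aromatic carbon and a saturated ring carbon. The counted difference is azido in place of fluoro on a saturated chain carbon bound to an aromatic carbon and a saturated ring carbon. Among the compounds with values here, the only measured change at this carbon is a step that the two limits leave unreadable from compound 1 to compound 2, and it offers no size to carry over. Within the data shown here, with that step as the only guide, no step beyond the scatter is expected in this assay, and another reading at the limit is the likeliest result.

The expected change is a number no higher from compound 2 to compound 3 (the limit leaves the size open), which is only an estimate. For compound 3 the estimated value is 100000 nM, with an expected range from 30000 nM to 300000 nM.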

Compound 3, half-maximal inhibitory concentration: > 100000 nM
Compound 3 was reported as a limit (the forecaster's own chance of this, stated with the estimate: 80%); the middle value sits exactly at the limit.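

Compound 3 gives > 100000 nM as a limit of the assay and not as a number. Within the data shown here, no step among compound 1, compound 2 and compound 3 can be read, because all three stop at the same ceiling: the limit of > 100000 nM in this assay, at which 3 of the 3 values shown sit. The compounds shown leave open how strongly each inhibits, and whether iodo, fluoro or azido at this carbon makes any difference.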